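Benzyl in place of phenyl: notes on compound 3

The source may report more compounds than this note shows. Statements on the series, on what has been measured and on what is new or still open speak of the compounds shown alone.

In a functional assay on HL-60 cells (Homo sapiens) for cytotoxicity, read by luminescence and CellTiter-Glo, with a stated time of 3 days (on this read-out higher numbers stand for weaker inhibition and lower numbers for stronger inhibition), compound 1 (`N#Cc1ccc(NC(=O)c2cc(-c3ccccc3)ccc2O)cc1`) gives 1350 nM and compound 2 (`N#Cc1ccc(NC(=O)c2ccc3cccnc3c2O)c(F)c1`) gives 730 nM, two values within the scatter of each other. Compound 3 (`N#Cc1ccc(NC(=O)c2cc(Cc3ccccc3)ccc2O)cc1`) differs from compound 1 in one place: benzyl in place of phenyl on an aromatic carbon. Among the compounds with values here, the series so far holds no measured pair that shows the size of such a change. In this assay, as far as these compounds go, no step beyond the scatter is expected, and the direction remains open. The estimated step is a 1.2-fold higher number from compound 1 to compound 3 (0.07 log units; within the scatter). Compound 3 is expected at 1600 nM, within an estimated range of 550 nM to 4500 nM.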

Compound 3, half-maximal inhibitory concentration: 1740 nM
The estimate for compound 3 lay 1.1-fold (0.04 log units) below the measured number; the range from low to high includes it.
By their numbers in this assay, from the lowest: compounds 2, 1 and 3 (each within the scatter of the next, the first and the last beyond it).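

The series now holds its first measured pair for this change: in this assay, benzyl in place of phenyl, on an aromatic carbon para to a hydroxy group, gives a 1.3-fold higher number from compound 1 to compound 3 (0.11 log units; within the scatter), so this read-out does not tell the two groups apart at this position. No measurement at hand bears on why.

As far as these compounds go, whether this position answers to anything other than a six-membered aromatic ring of carbon only stays open: an amine, a carboxylic acid or a longer chain here could give a step beyond the scatter, or none. A single pair also leaves open whether the same change behaves alike on another core.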